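This account rests on a few compounds, and the source may have more. Where it says the series, first, only, none or still open, it means among the compounds named here.

Within the data shown here, compound 2 `NC(CCCCB(O)O)(C(=O)O)C1CCN(Cc2ccc(Cl)cc2)CC1` gives 240 nM in an assay on isolated protein for inhibition of Arginase-2, mitochondrial (Homo sapiens), read by colorimetric assay, with a stated time of 1 h (a lower number here means a stronger inhibitor, a higher number a weaker inhibitor), and is the higher of the two numbers so far, though the gap to compound 1 is within the scatter. Among the measured compounds shown here, compound 1 `CC(C)CCN1CCC(C(N)(CCCCB(O)O)C(=O)O)CC1` gives 230 nM in this assay, and the change a 1.0-fold higher number from compound 1 to compound 2 (0.02 log units; within the scatter) is the only measured step in this region. Compound 3 `NC(CCCCB(O)O)(C(=O)O)C1CCN(Cc2ccc(Cl)c(Cl)c2)CC1` carries chloro in place of hydrogen on an aromatic carbon. For the measured compounds named here, since the one step that touches this part of the molecule was within the scatter, the change to compound 3 is expected to be a 1.1-fold lower number from compound 2 to compound 3 (0.04 log units; within the scatter), without a shift beyond the scatter. Compound 3 is estimated at 220 nM, with a range of 100 nM to 500 nM.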

Compound 3, half-maximal inhibitory concentration in the Arginase-2, mitochondrial assay: 290 nM
Beside the measured number, compound 3's estimate is 1.3-fold (0.12 log units) below it; measured number inside the range.
By their numbers in the Arginase-2, mitochondrial assay, from the lowest: compounds 1, 2 and 3 (each within the scatter of the next).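

In the Arginase-2, mitochondrial assay the added chloro, ortho to a chloro group and meta to a large group, leaves inhibition level, with a 1.2-fold higher number from compound 2 to compound 3 (0.08 log units; within the scatter) and, against the isobutyl end, a 1.3-fold higher number from compound 1 to compound 3 (0.10 log units; within the scatter). This aromatic carbon therefore takes the chloro with no shift in inhibition beyond the scatter, while a physicochemical assay for lipophilicity, using the shake flask method, in phosphate buffer, measured as octanol-water partition (on this read-out higher numbers stand for higher lipophilicity and lower numbers for lower lipophilicity), separates the pair: the measured distribution coefficient of compound 2, 0.3, and of compound 3, 1.5, a number 1.20 log units higher (beyond the scatter). In the physicochemical assay compound 2 gives 0.3 and compound 3 gives 1.5.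

Open, from the compounds shown here alone, is how a methoxy group or a nitrile on this aromatic carbon would read for inhibition and for distribution. Also open, going by these compounds, is whether inhibition holds with a carboxylic acid on the benzyl ring.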